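A few compounds are considered here, and "the series" means these few. Any claim that something is new, unique, unknown or untested is made for them only; others in the source may bear on it.

Of the compounds shown here, two have so far been measured in an assay on cells for inhibition of sodium- and chloride-dependent glycine transporter 1 (Homo sapiens); a higher number here means that more compound is needed for the effect, a lower number that less compound is needed. Compound 1 `COc1cc(C(F)(F)F)cc(C(F)(F)F)c1C(=O)NC1(c2ccccc2)CCCN(CC2CC2)C1` gives 380 nM, and compound 2 `COc1cc(C(F)(F)F)cc(SC)c1C(=O)NC1(c2ccc(C)cc2)CCCN(C)C1` gives 230 nM; these two numbers lie within the usual scatter of one another, so compound 2 stands on a par with compound 1. Compound 3 `COc1cc(C(F)(F)F)cc(SC)c1C(=O)NC1(c2cnccn2)CCCN(C)C1` differs from compound 2 in a single place: pyrazin-2-yl in place of 4-methylphenyl on a saturated ring carbon. Among the compounds with values here, no measured pair shows this kind of change, so its effect is uncertain. The step expected in this assay is a 2.6-fold higher number from compound 2 to compound 3 (0.42 log units; beyond the scatter), a rise somewhat beyond the scatter. In this assay compound 3 is estimated at 600 nM, with a range from 150 nM to 2500 nM.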

Compound 3, half-maximal effective concentration: 1670 nM
Beside the measured number, compound 3's estimate is 2.8-fold (0.44 log units) below it; measured number inside the range.
By their numbers in this assay, from the lowest: compounds 2 and 1 (each within the scatter of the next); then compound 3.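

On a saturated ring carbon, two ring bonds from the ring nitrogen, pyrazin-2-yl in place of 4-methylphenyl gives a 7.3-fold higher number from compound 2 to compound 3 (0.86 log units; beyond the scatter) in this assay, so the number here does respond to the group at this position. Compound 1 and compound 2 differ in several places and could not show this. Nothing measured here explains the rise. Going by these compounds, whether it follows the ring nitrogens or the loss of the methyl stays open, as does how a pyridin-2-yl or 4-fluorophenyl group would fare here.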